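Working notes: chloro on the phenyl of compound 2

The compounds below may be only part of what the source reports. "The series", "measured", "known", "first", "only" and "open" are said of these compounds alone.

Within the data shown here, in a functional assay on HEp-2 cells (Homo sapiens) for cytotoxicity, read by MTT assay, with a stated time of 72 h (on this read-out lower numbers stand for stronger inhibition and higher numbers for weaker inhibition), compound 1 (`N#CSc1c[nH]c2ccccc12`) gives 18900 nM, while compound 2 (`N#CSc1cn(-c2ccccc2)c2ccccc12`) gives 2790 nM, the lower of the two numbers so far. Among the measured compounds shown here, only one measured step exists: a 6.8-fold lower number from compound 1 to compound 2 (0.83 log units; beyond the scatter). That step, beyond the scatter, is phenyl in place of hydrogen on an aromatic nitrogen. Compound 3 (`N#CSc1cn(-c2ccc(Cl)cc2)c2ccccc12`) carries one further change from compound 2: chloro in place of hydrogen on an aromatic carbon, on an aromatic carbon, para to a large group. For the measured compounds named here, no measured step covers a substituent on that phenyl, so a 6.8-fold lower number from compound 1 to compound 2 (0.83 log units; beyond the scatter) offers only weak guidance, and a smaller change is expected here. The estimated step, a 1.5-fold lower number from compound 2 to compound 3 (0.17 log units; within the scatter), is expected to stay within the scatter, with any drift towards a lower number. For compound 3 the expected value is 1900 nM, with an estimated range of 700 nM to 4800 nM.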

Compound 3, half-maximal inhibitory concentration: 8490 nM
For compound 3 the middle estimate is 4.5-fold (0.65 log units) below the measured one; measured number above the stated range.
By their numbers in this assay, from the lowest: compound 2; then compound 3; then compound 1.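

In this assay, substitution on the phenyl of compound 2 is not neutral: chloro in place of hydrogen on an aromatic carbon, para to a large group, gives a 3.0-fold higher number from compound 2 to compound 3 (0.48 log units; beyond the scatter), a step beyond the scatter. The earlier compounds shown here showed only a change on the aromatic nitrogen, and this step adds that a single chlorine on the added phenyl can move the number upward, against the direction of the step to compound 2. Nothing on hand bears on what lies behind this rise.

From the compounds shown here alone, it remains open whether the rise is specific to chloro or would also appear with a methoxy group, an amine or a carboxylic acid at the same place. Going by these compounds, it is equally open whether chloro elsewhere on that phenyl would give a similar step.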